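Changing the aryl amine of a quinazoline-linked sulfonamide

A few compounds are considered here, and "the series" means these few. Any claim that something is new, unique, unknown or untested is made for them only; others in the source may bear on it.

Of the compounds shown here, three sharing one core have been measured in a functional assay on A549 cells (Homo sapiens) for antiproliferative activity, read by MTT assay, with a stated time of 72 h; on this read-out higher numbers stand for weaker inhibition and lower numbers for stronger inhibition. Compound 1 `COc1cc2ncnc(Nc3ccc(F)c(Cl)c3)c2cc1OCCCCC(=O)Nc1ccc(S(N)(=O)=O)cc1` gives 15500 nM. Compound 2 `COc1cc2ncnc(Nc3ccc(Cl)c(C(F)(F)F)c3)c2cc1OCCCCC(=O)Nc1ccc(S(N)(=O)=O)cc1` gives 9270 nM, the lowest of the three numbers. Compound 3 `COc1ccccc1Nc1ncnc2cc(OC)c(OCCCCC(=O)Nc3ccc(S(N)(=O)=O)cc3)cc12` gives 24100 nM. The step of a 1.7-fold lower number from compound 1 to compound 2 (0.22 log units; within the scatter) lies within the usual scatter, as does a 1.6-fold higher number from compound 1 to compound 3 (0.19 log units; within the scatter), while a 2.6-fold higher number from compound 2 to compound 3 (0.41 log units; beyond the scatter) is a modest step beyond it. Compound 2 therefore stands apart from compound 3 but not clearly from compound 1.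

Compound 4 `CCc1ccc(Nc2ncnc3cc(OC)c(OCCCCC(=O)Nc4ccc(S(N)(=O)=O)cc4)cc23)cc1` has not yet been measured. It differs from compound 2 at the aromatic amine: 4-ethylphenyl in place of 4-chloro-3-(trifluoromethyl)phenyl on a nitrogen on an aromatic ring. Among the compounds with values here, the group that enters carries no halogen, unlike the groups in compound 1 and compound 2, and the only measured change at this position that moved the number beyond the scatter, a 2.6-fold higher number from compound 2 to compound 3 (0.41 log units; beyond the scatter), gave a higher number when the halogen-bearing group was exchanged. Within the data shown here, only three compounds speak to this position, so the expectation is loose. Compound 4 is expected in this assay to give a somewhat higher number than compound 2, with a 1.7-fold higher number from compound 2 to compound 4 (0.24 log units; within the scatter) as the estimated step, most likely near 16000 nM and within the range 6000 nM to 45000 nM.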

Compound 4, half-maximal inhibitory concentration: 12100 nM
Estimate against measurement, compound 4: 1.3-fold (0.12 log units) above, and the stated range covers the measured number.
By their numbers in this assay, from the lowest: compounds 2, 4, 1 and 3 (each within the scatter of the next, the first and the last beyond it).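

In this assay, replacing the halogen-bearing 4-chloro-3-(trifluoromethyl)phenyl with 4-ethylphenyl, a group of carbon only, gives a step within the scatter (a 1.3-fold higher number from compound 2 to compound 4 (0.12 log units; within the scatter)), so at this position a halogen is not required for a number that cannot be told apart from that of compound 2. Within the data shown here, compound 4 also cannot be separated from the other two compounds (a 1.3-fold lower number from compound 1 to compound 4 (0.11 log units; within the scatter) and a 2.0-fold lower number from compound 3 to compound 4 (0.30 log units; within the scatter)), and it therefore sits within the scatter of both ends of the one step that exceeds it (a 2.6-fold higher number from compound 2 to compound 3 (0.41 log units; beyond the scatter)), which means that step cannot be put down simply to the absence of halogen on the ring. Nothing available explains why these four numbers fall where they do.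

Going by these compounds, it remains open whether a ring carrying an amine or a carboxylic acid, or a longer chain in place of the ethyl group, would move the number clearly beyond the scatter. On these data alone, it is also open whether 4-ethylphenyl would behave the same way with a shorter or longer chain leading to the sulfonamide.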